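A few compounds are considered here, and "the series" means these few. Any claim that something is new, unique, unknown or untested is made for them only; others in the source may bear on it.

Compound 2 `FC(F)(F)c1cc(C2CO2)cc(C(F)(F)F)c1` stands at the longer-lived end of the two measured values. In an ADME assay for pharmacokinetics, read by LC-MS, in phosphate buffer, with a stated time of 72 h, at pH 7.4, tested at 250 uM (on this read-out lower numbers stand for a shorter-lived compound and higher numbers for a longer-lived compound), compound 2 gives > 50 h, which is a limit of the assay rather than a number. Compound 1 `C=CS(=O)(=O)c1cc(C(F)(F)F)cc(C(F)(F)F)c1` also sits at a limit, giving < 0.017 h. Going by the values given here, the one measured step, an at least 2900-fold higher number from compound 1 to compound 2 (3.46 log units; beyond the scatter), rests on the limits the limit of < 0.017 h in this assay, at which 1 of the 2 values shown sits, and (the limit of > 50 h in this assay, at which 1 of the 2 values shown sits). Compound 3 `Fc1cc(C(F)(F)F)cc(C(F)(F)F)c1` differs from compound 2 by fluoro in place of oxiran-2-yl on an aromatic carbon. Among the compounds with values here, no measured step removes the oxiran-2-yl group, so no step beyond the scatter is expected in this assay. The estimate for compound 3 is 50 h, with a range from 15 h to 50 h. The step this implies, a number no higher from compound 2 to compound 3 (the limit leaves the size open), is expected to stay within the scatter.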

Compound 3, half-life: > 50 h
Compound 3: no number, only a limit; the forecaster's own chance of this, stated with the estimate: 85%; the middle value sits exactly at the limit.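

In this assay compound 3 gives > 50 h, which is a limit of the assay and not a number. Fluoro on this aromatic carbon therefore reads the same as oxiran-2-yl, and the step between compound 2 and compound 3 cannot be read: the limit of > 50 h in this assay, at which 2 of the 3 values shown sit. Fluoro in place of vinylsulfonyl gives an at least 2900-fold higher number from compound 1 to compound 3 (3.46 log units; beyond the scatter), and the size of that step rests on a limit at its low end: the limit of < 0.017 h in this assay, at which 1 of the 3 values shown sits. How far compound 2 and compound 3 really lie beyond the limit stays open. So does where an amine or a carboxylic acid on this carbon of the shared core would fall in this assay.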